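The source may hold more compounds than are shown below. What is called first, only, known or untested is meant among the compounds shown, and "the series" means these compounds.

Measured compounds in a functional assay; on this read-out higher numbers stand for weaker inhibition and lower numbers for stronger inhibition
Compound 1 `CC(C)=CCOc1ccc2c(c1)OC(c1ccc(O)cc1)CC2=O` gives 6670 nM
Compound 2 `CC(C)=CCOc1cc(O)c2c(c1)OC(c1cccc(F)c1)CC2=O` gives 7240 nM
Compound 3 `CC(C)=CCOc1cc(O)c2c(c1)OC(c1ccccc1Br)CC2=O` gives 3820 nM

At 3820 nM in this assay, compound 3 lies within the scatter of both other compounds. Compound 4 `CC(C)=CCOc1cc(O)c2c(c1)OC(c1ccc(O)cc1)CC2=O` has not yet been measured. It carries 4-hydroxyphenyl in place of 2-bromophenyl on a saturated ring carbon and keeps the rest of compound 3 unchanged. Among the compounds with values here, one measured step bears on this, an exchange of groups on the same carbon: a 1.9-fold lower number from compound 2 to compound 3 (0.28 log units; within the scatter) stays within the scatter. Compound 1, which also carries 4-hydroxyphenyl, gives 6670 nM on a core that differs from that of compound 4. No step beyond the scatter is therefore expected, and the estimated step is a 1.3-fold higher number from compound 3 to compound 4 (0.12 log units; within the scatter) in size. The estimate for compound 4 is 5000 nM, with an expected range from 2200 nM to 11500 nM.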

Compound 4, half-maximal inhibitory concentration: 5340 nM
For compound 4 the middle estimate is 1.1-fold (0.03 log units) below the measured one, within the range that was stated.
By their numbers in this assay, from the lowest: compounds 3, 4, 1 and 2 (each within the scatter of the next).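

In this assay, the saturated ring carbon next to the ring oxygen accepts 4-hydroxyphenyl as well as 2-bromophenyl and 3-fluorophenyl: a 1.4-fold higher number from compound 3 to compound 4 (0.15 log units; within the scatter) and a 1.4-fold lower number from compound 2 to compound 4 (0.13 log units; within the scatter) both stay within the scatter, even though a hydrogen-bond donor and acceptor enter with the new group. Hydroxy in place of hydrogen on an aromatic carbon of the core gives a 1.2-fold lower number from compound 1 to compound 4 (0.10 log units; within the scatter) and also stays within the scatter. From the compounds shown here alone, whether an aminophenyl or a cyclohexyl group at that carbon would move the number beyond the scatter remains open. No supporting measurement accounts for these values.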